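Notes on the amide ring series, from compound 2 to compound 3

The compounds below may be only part of what the source reports. "The series", "measured", "known", "first", "only" and "open" are said of these compounds alone.

Within the data shown here, compound 2 `CN1CCN(C(=O)CCSc2nc3cc(Cl)ccc3o2)CC1` gives 41.5 mL/min/g in an ADME assay on microsomes from liver (Mus musculus) for metabolic stability, read by LC-MS, using NADPH, with a stated time of 45 min, tested at 0.5 uM (a higher number here means faster removal of the compound, a lower number slower removal), the lowest of the two numbers measured so far. Compound 1 `O=C(CCSc1nc2cc(Cl)ccc2o1)N1CCCCC1` gives 128 mL/min/g in this assay. Among the measured compounds shown here, the one measured step, a 3.1-fold lower number from compound 1 to compound 2 (0.49 log units; beyond the scatter), is the only comparison available. Compound 3 `CS(=O)(=O)N1CCN(C(=O)CCSc2nc3cc(Cl)ccc3o2)CC1` differs from compound 2 by methylsulfonyl in place of methyl on an amine nitrogen in a ring. The step from compound 1 to compound 2 exchanged the whole ring on the carbonyl carbon, whereas the change to compound 3 keeps the ring of compound 2 and alters only the group on its amine nitrogen. For the measured compounds named here, no measured step covers a swap of this kind, so the earlier step offers only a rough sense of how far a change in this part of the molecule can move this assay. Going by the values given here, with no direct precedent, compound 3 is expected to show a step of a 1.2-fold higher number from compound 2 to compound 3 (0.08 log units; within the scatter), with no direction claimed beyond the scatter. The estimate for compound 3 in this assay is 50 mL/min/g, within 20 mL/min/g to 130 mL/min/g.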

Compound 3, intrinsic clearance in a liver preparation (reported as CLH), per the amount of preparation that the assay uses: 1.4 mL/min/g
Beside the measured number, compound 3's estimate is 36-fold (1.55 log units) above it; measured number outside the range, below it.
By their numbers in this assay, from the lowest: compound 3; then compound 2; then compound 1.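

In this assay, among these compounds, the group on the amine nitrogen in the ring turns out to be a far more sensitive place than the one earlier comparison could show: a 30-fold lower number from compound 2 to compound 3 (1.47 log units; beyond the scatter) is a large step, whereas a 3.1-fold lower number from compound 1 to compound 2 (0.49 log units; beyond the scatter) is a modest one, even though that earlier step exchanged the whole ring on the carbonyl carbon. The ring of compound 2 and the rest of the molecule stay the same in compound 3, so this single exchange of methyl for methylsulfonyl, which brings in 4 heavy atoms and 2 hydrogen-bond acceptors, is the only structural difference that goes with the drop in the number. Among the compounds shown here, nothing at hand explains why this exchange moves the number so far.

Going by these compounds, it remains open whether the low number is particular to methylsulfonyl or would also appear with an acetyl, a methoxycarbonyl or a larger sulfonyl such as phenylsulfonyl on the same nitrogen. On these data alone, it is also open whether the step would keep its size with the chlorine on the core replaced by fluorine or with a longer chain leading to the carbonyl.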